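This account rests on a few compounds, and the source may have more. Where it says the series, first, only, none or still open, it means among the compounds named here.

Measured so far:
Compound 1 `Cc1c(O)ccc2c1[C@H](Cn1cc(-c3ccc(F)cc3)nn1)[C@@]13CC(=O)[C@@](C)(CC[C@@H]21)C3`: > 20000 nM in a functional assay on MCF7 cells (Homo sapiens) for cytotoxicity, read by MTT assay, with a stated time of 4 days (on this read-out lower numbers stand for stronger inhibition and higher numbers for weaker inhibition), a limit only.
Compound 2 `C=C1C[C@]23C[C@@]1(O)CC[C@H]2c1cc(Br)c(O)c(C)c1[C@@H]3Cn1cc(-c2ccc(F)cc2)nn1`: 19200 nM in this assay.
Compound 3 `C=C1C[C@]23C[C@@]1(O)CC[C@H]2c1ccc(O)c(C)c1[C@@H]3Cn1cc(-c2ccc(F)cc2)nn1`: > 20000 nM in this assay, a limit only.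

Going by the values given here, compound 2 holds the only number in this assay; the other two values are limits, as the limit of > 20000 nM in this assay, at which 2 of the 3 values shown sit, shows. Among the compounds with values here, the single measured step, an at least 1.0-fold higher number from compound 2 to compound 3 (0.01 log units; that floor lies within the scatter), lies within the scatter. Compound 4 `C=C1C[C@]23C[C@@]1(O)CC[C@H]2c1cc(Br)c(O)c(C)c1[C@@H]3Cn1cc(-c2ccc(Cl)cc2)nn1` differs from compound 2 by chloro in place of fluoro on an aromatic carbon. No measured step touches this position, so nothing bears on it directly, and the bromo-to-hydrogen step gives no reason to expect a large move. In this assay compound 4 is therefore expected at 18000 nM, range 7000 nM to 40000 nM. The expected step of a 1.1-fold lower number from compound 2 to compound 4 (0.03 log units; within the scatter) stays within the scatter, and a limit rather than a number remains a real possibility for compound 4.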

Compound 4, half-maximal inhibitory concentration: 10200 nM
For compound 4 the middle estimate is 1.8-fold (0.25 log units) above the measured one; the range from low to high includes it.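

Going by these compounds alone, the 4-fluorophenyl to 4-chlorophenyl change gives the first reading at this position in this assay: a 1.9-fold lower number from compound 2 to compound 4 (0.27 log units; within the scatter). Chloro and fluoro on this ring, para to a large group, are therefore not told apart here. Like compound 2, compound 4 gives a number rather than a limit.

Open, as far as these compounds go, is whether an amine, a carboxylic acid or a longer chain in place of chloro gives a number clearly apart from these. Also open is how far the series can be ranked at all, given this bound: the limit of > 20000 nM in this assay, at which 2 of the 4 values shown sit.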